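Bromination of a naphthyl ether pair under cytotoxicity screening

The compounds below may be only part of what the source reports. "The series", "measured", "known", "first", "only" and "open" are said of these compounds alone.

The series is followed in an ADME assay on MT4 cells (Homo sapiens) for cytotoxicity, read by MTT assay, with a stated time of 4 days; on this read-out lower numbers stand for higher toxicity in this test and higher numbers for lower toxicity in this test. Compound 1 `Cc1cnc(Nc2ccc(C#N)cc2)nc1Oc1ccc2cc(C#N)ccc2c1` is the reference point. In this assay compound 1 gives > 331000 nM, which is a limit of the assay and not a number. Compound 2 `Cc1cnc(Nc2ccc(C#N)cc2)nc1Oc1ccc2cc(C#N)ccc2c1Br` differs from compound 1 by bromo in place of hydrogen on an aromatic carbon. In this assay compound 2 gives > 274000 nM, again a limit. Compound 3 `N#Cc1ccc(Nc2nccc(Oc3ccc4cc(C#N)ccc4c3)n2)cc1` differs from compound 1 in the core, by hydrogen in place of methyl on an aromatic carbon. In this assay compound 3 gives > 68800 nM, also a limit. Both measured steps, a step that the two limits leave unreadable from compound 1 to compound 2 and a step that the two limits leave unreadable from compound 1 to compound 3, therefore remain unreadable.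

Compound 4 `N#Cc1ccc(Nc2nccc(Oc3cc4ccc(C#N)cc4cc3Br)n2)cc1` is not yet measured; it arises from compound 3 by bromo in place of hydrogen on an aromatic carbon. This is the same kind of change as from compound 1 to compound 2, but not the same: there the place was ortho to a fused ring, ortho to a large group and meta to a fused ring, here it is ortho to a large group, meta to a fused ring and para to a fused ring.

For compound 4 a step that the limit leaves unreadable from compound 3 to compound 4 is expected. That expectation rests on compound 1, whose value sits at the limit of > 331000 nM in this assay, at which 1 of the 3 values shown sits. It rests equally on compound 2, whose value sits at the limit of > 274000 nM in this assay, at which 1 of the 3 values shown sits, so the same kind of change left the read-out at a limit once already. Compound 4 is therefore expected to give 150000 nM, between 50000 nM and 400000 nM, and most probably to be reported only as a limit.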

Compound 4, half-maximal cytotoxic concentration: > 56500 nM
Compound 4: a limit, no number (the forecaster's own chance of this, stated with the estimate: 80%); the middle value lies beyond the limit too.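

Compound 3 and compound 4 are both reported only as limits in this assay, so no new step can be read between them. The compounds shown leave open where any of the four would give an actual half-maximal cytotoxic concentration, and whether bromo in place of hydrogen on an aromatic carbon shifts the read-out at either place.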